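A few compounds are considered here, and "the series" means these few. Any claim that something is new, unique, unknown or untested is made for them only; others in the source may bear on it.

Compound 1 `CCN1CCN(S(=O)(=O)CCCN2CCC(CNC(=O)c3cccc4c3OCCO4)CC2)CC1` gives 0.0501 nM in an assay on isolated protein for inhibition of 5-hydroxytryptamine receptor 4 (Homo sapiens) (on this read-out lower numbers stand for stronger inhibition and higher numbers for weaker inhibition), and compound 2 `CC1(C)CCN(S(=O)(=O)CCCN2CCC(CNC(=O)c3cccc4c3OCCO4)CC2)CC1` gives 0.126 nM. Among the measured compounds shown here, the single measured step, a 2.5-fold higher number from compound 1 to compound 2 (0.40 log units; beyond the scatter), exchanges the whole ring on the sulfonyl sulfur. Compound 1 thus holds the lowest of the two numbers, with compound 2 nearest to it and beyond the scatter. Compound 3 `CS(=O)(=O)N1CCN(S(=O)(=O)CCCN2CCC(CNC(=O)c3cccc4c3OCCO4)CC2)CC1` keeps the ring of compound 1 and alters only the group on the amine nitrogen in that ring: methylsulfonyl in place of ethyl on an amine nitrogen in a ring. For the measured compounds named here, no measured step changes a substituent on that ring nitrogen; the step from compound 1 to compound 2 is the only related one, and it shows a modest move in this assay when this end of the molecule is altered. A step of similar or smaller size is expected, most likely toward a higher number, a 2.0-fold higher number from compound 1 to compound 3 (0.30 log units; within the scatter). Compound 3 is therefore estimated at 0.1 nM, within 0.03 nM to 0.4 nM.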

Compound 3, inhibition constant: 0.316 nM
Compound 3: middle estimate off by 3.2-fold (0.50 log units), on the low side, within the range that was stated.
By their numbers in this assay, from the lowest: compound 1; then compound 2; then compound 3.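

In this assay the group on the ring nitrogen counts on its own: with the ring kept, methylsulfonyl in place of ethyl gives a 6.3-fold higher number from compound 1 to compound 3 (0.80 log units; beyond the scatter) and so moves the number further than the earlier exchange of the whole ring did. The 4-(methylsulfonyl)piperazin-1-yl group also falls behind 4,4-dimethylpiperidin-1-yl, with a 2.5-fold higher number from compound 2 to compound 3 (0.40 log units; beyond the scatter), so all three groups on the sulfonyl sulfur now stand in one order beyond the scatter, with compound 3 holding the highest number. No evidence on this change is available.

Going by these compounds, with a single sulfonyl example, it stays open whether the rise belongs to the methylsulfonyl group or simply to the loss of ethyl. An acetyl group, a propyl chain or a free ring amine on that nitrogen would bear on this question.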